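This account rests on a few compounds, and the source may have more. Where it says the series, first, only, none or still open, it means among the compounds named here.

In a functional assay (aorta) with Rattus norvegicus as the target (a lower number here means a stronger inhibitor, a higher number a weaker inhibitor), compound 1 (`CCCCCCCCN(CCCCCCCC)CCCOc1ccc(S(=O)(=O)c2c(C(C)C)cn3ccccc23)cc1`) gives 30100 nM and compound 3 (`CC(C)(C)NCCCOc1ccc(S(=O)(=O)c2c(C(C)(C)C)cn3ccccc23)cc1`) gives 443 nM while compound 2 (`CCCCN(CCCC)CCCCOc1ccc(S(=O)(=O)c2c(C(C)C)cn3ccccc23)cc1`) gives 20.2 nM as the lowest number of the three. Its gaps to both others lie beyond the usual scatter of repeat measurements, so compound 2 is the strongest inhibitor so far.

Compound 4 (`CCCN(CCC)CCCOc1ccc(S(=O)(=O)c2c(C(C)C)cn3ccccc23)cc1`) has not yet been measured. Compared with compound 2, it has dipropylamino in place of (dibutylamino)methyl on a saturated chain carbon, three bonds along the chain from an oxygen on an aromatic ring.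

Within the data shown here, no two measured compounds differ in one place only, so the data give no direct guide to the size of this step. The wide spread of the values, with compound 1 at 30100 nM as the far end, argues for caution. A modest rise in the number is expected (a 2.2-fold higher number from compound 2 to compound 4 (0.35 log units; beyond the scatter)) but remains uncertain. For compound 4 the estimated value is 45 nM with 10 nM to 250 nM as the expected range.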

Compound 4, half-maximal inhibitory concentration: 102 nM
For compound 4 the middle estimate is 2.3-fold (0.36 log units) below the measured one, within the range that was stated.
By their numbers in this assay, from the lowest: compound 2; then compound 4; then compound 3; then compound 1.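

In this assay, putting dipropylamino in place of (dibutylamino)methyl gives a 5.0-fold higher number from compound 2 to compound 4 (0.70 log units; beyond the scatter), so this first comparison of compounds differing in one place shows that the change on this saturated chain carbon moves the number beyond the scatter. The group that leaves has 10 heavy atoms and the one that enters has 7, while both have no ring, no net charge, 0 hydrogen-bond donors and 1 hydrogen-bond acceptor, so the shift comes with a change in group size and not in these counts. Nothing measured here explains the shift in the number.

This single step changes the alkyl groups on the nitrogen and removes the methyl of the leaving group together, so the two changes cannot be told apart. Going by these compounds, how a diethylamino group or a piperidine ring would read at this place remains open.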